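The compounds below may be only part of what the source reports. "The series", "measured", "known", "first", "only" and "open" are said of these compounds alone.

Three compounds built on the shared core were examined in a functional assay on A-427 cells (Homo sapiens) for antiproliferative activity, read by crystal violet staining, with a stated time of 96 h; on this read-out lower numbers stand for stronger inhibition and higher numbers for weaker inhibition. Compound 1 `O=C1/C(=C2/C(=O)N([C@@H]3O[C@H](CO)[C@@H](O)[C@H](O)[C@H]3O)c3ccccc32)Nc2ccccc21` gives 11800 nM. Compound 2 `O=C1/C(=C2/C(=O)N([C@@H]3O[C@H](CO)[C@@H](O)[C@H](O)[C@@H]3O)c3ccccc32)Nc2ccccc21` gives 5550 nM, the lowest of the two numbers obtained; the step of a 2.1-fold lower number from compound 1 to compound 2 (0.33 log units; beyond the scatter) rests on (the fact that compounds 1 and 2 differ only in the configuration as drawn). Compound 3 `Cc1cc(C)c2c(c1)N([C@H]1O[C@@H](C)[C@H](O)[C@@H](O)[C@H]1O)C(=O)/C2=C1\Nc2ccccc2C1=O` was also prepared, but in this assay compound 3 gives "not determined" (no result reported), so no number was reported for it.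

Compound 4 `O=C1/C(=C2/C(=O)N([C@@H]3O[C@H](CO)[C@H](O)[C@H](O)[C@H]3O)c3ccccc32)Nc2ccccc21` is the next compound to be measured. Compared with compound 2, (the two compounds have the same atoms and bonds and differ only in configuration as drawn: 2 of 6 stereo elements differ; a stereocentre at a saturated ring carbon is drawn S in compound 2 and R in compound 4; a stereocentre at a saturated ring carbon is drawn S in compound 2 and R in compound 4). Among the compounds with values here, only one measured step bears on this change, namely a 2.1-fold lower number from compound 1 to compound 2 (0.33 log units; beyond the scatter), which shows that altering the configuration at one saturated ring carbon shifted the number modestly. Since compound 4 alters two such centres and the direction of any effect is not predictable from a single step, the expected step of a 1.4-fold higher number from compound 2 to compound 4 (0.16 log units; within the scatter) in this assay is of similar modest size, most likely no further than the scatter, with the direction uncertain. Compound 4 is therefore estimated to give 8000 nM, in the range 3000 nM to 25000 nM.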

Compound 4, half-maximal inhibitory concentration: 13200 nM
Compound 4: the middle estimate sits 1.7-fold (0.22 log units) below what was measured; the measured number falls inside the stated range.
By their numbers in this assay, from the lowest: compound 2; then compounds 1 and 4 (each within the scatter of the next).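

Changing the second saturated ring carbon on its own, with the first centre left as in compound 1, moves nothing measurable in this assay: a 1.1-fold higher number from compound 1 to compound 4 (0.05 log units; within the scatter). Altering both centres together gives a shift beyond the scatter, a 2.4-fold higher number from compound 2 to compound 4 (0.38 log units; beyond the scatter), so compound 2 now has the lowest number of the three, with both of its steps beyond the scatter. Not every stereocentre in the sugar ring therefore counts alike here, though these numbers rest on configuration alone and no cause for the shift can be read from them: the fact that compounds 2 and 4 differ only in the configuration as drawn

As far as these compounds go, the remaining stereocentres of the ring stay open, as does whether the configuration of compound 2 would still give the lowest number with other substituents on the core. It is also unknown how an amine or a carboxylic acid in place of a ring hydroxyl would affect the number.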